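Chloro in place of fluoro on compound 2

A few compounds are considered here, and "the series" means these few. Any claim that something is new, unique, unknown or untested is made for them only; others in the source may bear on it.

Of the compounds shown here, two so far have numbers in a physicochemical assay for solubility, read by HPLC, in phosphate buffer, measured as kinetic solubility, at pH 7.4 (a lower number here means a less soluble compound, a higher number a more soluble compound), to set the scene. There compound 1 (`CCC(=O)c1cc(-c2ccc(Cl)cc2Cl)n(-c2ccc(S(N)(=O)=O)cc2)c1C`) gives 7700 nM while compound 2 (`CCC(=O)c1cc(-c2ccc(F)cc2)n(-c2ccc(S(N)(=O)=O)cc2)n1`) gives 88900 nM and so stands as the higher of the two, with a gap to compound 1 that lies beyond the scatter.

The next compound, compound 3 (`CCC(=O)c1cc(-c2ccc(Cl)cc2)n(-c2ccc(S(N)(=O)=O)cc2)n1`), comes from compound 2 by a single change: chloro in place of fluoro on an aromatic carbon, which reads as 4-fluorophenyl to 4-chlorophenyl. The two measured compounds differ from each other in more than one place, so they offer no direct measure of this swap, and any forecast rests on the structural change alone. A moderate fall in this assay is expected, a little beyond the scatter rather than a collapse. The estimated step of a 3.0-fold lower number from compound 2 to compound 3 (0.47 log units; beyond the scatter) is a downward one of that size. Compound 3 is estimated at 30000 nM within an expected range from 10000 nM to 80000 nM on this reading.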

Compound 3, solubility: 37800 nM
The estimate for compound 3 lay 1.3-fold (0.10 log units) below the measured number; the measured number falls inside the stated range.
By their numbers in this assay, from the lowest: compound 1; then compound 3; then compound 2.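

Going by these compounds alone, compound 3 supplies the first reading in this set of a single change, since in this assay the exchange of 4-fluorophenyl for 4-chlorophenyl amounts to a 2.4-fold lower number from compound 2 to compound 3 (0.37 log units; beyond the scatter) and so is modest in size yet beyond the scatter. The halogen on this aromatic carbon, para to a large group, therefore matters to this read-out, even though the count of heavy atoms, hydrogen-bond donors and acceptors and the net charge all stay the same across the change. No measurement shown bears on what lies behind the step, which stands here as an observation alone.

Compound 1 differs from the other two compounds in more than one place, so its value cannot say whether the same exchange would give a step of similar size on the core of compound 1. How the number would move with a methoxy group, a nitrile or an amine at this same position also stays open, as the compounds shown carry only fluoro and chloro there on the shared core of compound 2 and compound 3.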